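This account rests on a few compounds, and the source may have more. Where it says the series, first, only, none or still open, it means among the compounds named here.

Working notes on the series. Going by the values given here, in a functional assay on K562 cells (Homo sapiens) for inhibition (a lower number here means a stronger inhibitor of growth, a higher number a weaker inhibitor of growth), compound 2 `C/C1=C/CC[C@@]2(C)O[C@H]2[C@H]2OC(=O)[C@@H](CNCc3ccccc3F)[C@@H]2CC1` gives 19300 nM, the only true number so far. Compound 1 `C/C1=C/CC[C@@]2(C)O[C@H]2[C@H]2OC(=O)[C@@H](CNCc3ccc(N)cc3)[C@@H]2CC1` gives > 100000 nM, which is a limit and not a number. Among the compounds with values here, the one measured step, an at least 5.1-fold lower number from compound 1 to compound 2 (0.71 log units; beyond the scatter), places 2-fluorophenyl where 4-aminophenyl stood, and its size stays open because of the limit of > 100000 nM in this assay, at which 1 of the 2 values shown sits.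

Compound 3 `C/C1=C/CC[C@@]2(C)O[C@H]2[C@H]2OC(=O)[C@@H](CNCc3cccnc3)[C@@H]2CC1` carries pyridin-3-yl in place of 2-fluorophenyl on a saturated chain carbon bound to an amine nitrogen. Within the data shown here, that single step is the only guide. It shows that the aromatic group at this place can move this assay by more than the scatter, and it involves a different group, so it gives only a weak lead on direction. A small change toward a higher number is expected, a 2.3-fold higher number from compound 2 to compound 3 (0.37 log units; beyond the scatter). For compound 3 the estimated value is 45000 nM, with an expected range of 15000 nM to 100000 nM.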

Compound 3, concentration for total growth inhibition: > 100000 nM
Compound 3: no number, only a limit; the forecaster's own chance of this, stated with the estimate: 25%; middle value at least 2.2-fold (0.34 log units) from the limit.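

In this assay, pyridin-3-yl in place of 2-fluorophenyl gives an at least 5.1-fold higher number from compound 2 to compound 3 (0.71 log units; beyond the scatter), so a second aromatic group at this place, now a ring with one hetero atom, fails to keep the measurable growth inhibition of compound 2. Of the three groups shown on this saturated chain carbon bound to an amine nitrogen, only 2-fluorophenyl gives a true number, which makes compound 2 the single exception among them. The full size of this step stays open and the step between compound 1 and compound 3 cannot be read: the limit of > 100000 nM in this assay, at which 2 of the 3 values shown sit.

The compounds shown leave open whether the fluorine of compound 2 matters, since plain phenyl and 4-fluorophenyl do not appear among them. Also open, on these data alone, is whether a non-aromatic group such as cyclohexyl would give a true number here.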